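Swapping an oxazole for a methyl oxime ether

A few compounds are considered here, and "the series" means these few. Any claim that something is new, unique, unknown or untested is made for them only; others in the source may bear on it.

Measured compounds:
compound 1 `Cc1ncc(-c2ccccc2NCC2=NCCN2)o1`, < 5020 nM
compound 2 `c1ccc(-c2cnoc2)c(NCC2=NCCN2)c1`, < 100000 nM
compound 3 `Cc1ccsc1-c1ccccc1NCC1=NCCN1`, 49 nM

In a functional assay for activation of Alpha-1D adrenergic receptor (Homo sapiens) (a lower number here means that less compound is needed, a higher number that more compound is needed for the effect), compound 1 gives only a limit, < 5020 nM, and so sits at the limit of < 5020 nM in this assay, at which 1 of the 3 values shown sits. Compound 2 likewise gives only a limit, < 100000 nM, and sits at the limit of < 100000 nM in this assay, at which 1 of the 3 values shown sits. Compound 3 alone gives a number, 49 nM. The steps among these three are all unreadable: a step that the two limits leave unreadable from compound 1 to compound 2, a step that the limit leaves unreadable from compound 1 to compound 3 and a step that the limit leaves unreadable from compound 2 to compound 3, each because at least one end of the step is a limit. Compound 1 therefore stands only as a limit, with one other limit beside it and one full number.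

Compound 4 `CO/N=C(\C)c1ccccc1NCC1=NCCN1` differs from compound 1 in one place: a group of 5 heavy atoms (3 carbon, 1 nitrogen, 1 oxygen; no ring) in place of a group of 6 heavy atoms (4 carbon, 1 nitrogen, 1 oxygen; one five-membered aromatic ring with 2 hetero atoms), on an aromatic carbon. Among the measured compounds shown here, no measured step covers this kind of change, so no step size can be carried over; the one full value, compound 3, shows that a ring of the shared core can reach 49 nM. Compound 4 is estimated at 600 nM, with a range from 60 nM to 6000 nM, which would mean a step that the limit leaves unreadable from compound 1 to compound 4 relative to the limit of compound 1, an expectation that rests on this assay alone and carries wide uncertainty.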

Compound 4, half-maximal effective concentration: < 5020 nM
Compound 4 ended at the assay's limit; the forecaster's own chance of this, stated with the estimate: 30%; the middle value lies beyond the limit too.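

In this assay, among the compounds shown here, compound 4 gives only a limit, < 5020 nM, so no step from compound 1, compound 2 or compound 3 to compound 4 can be read. The compounds shown leave open where compound 1, compound 2 and compound 4 truly stand relative to compound 3, the only one with a full number.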